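The source may hold more compounds than are shown below. What is called first, only, known or untested is meant among the compounds shown, and "the series" means these compounds.

Compound 1 `CC1=C(C(=O)OCc2ccccc2)C(c2cccs2)NC(=O)N1` gives 8% in an assay on membranes from HeLa cells for displacement of a labelled ligand from adenosine receptor A3 (Homo sapiens), read by scintillation counting, with a stated time of 180 min, tested at 1 uM; on this read-out higher numbers stand for more inhibition at the one concentration tested (going by the name of the read-out) and lower numbers for less inhibition.
Compound 2 `CCCOC(=O)C1=C(C)N(C)C(=O)NC1c1cccs1` gives 4% in this assay.
Compound 3 `CC1=C(C(=O)OC(C)C)C(c2cccs2)NC(=O)N1C` gives 17% in this assay.

Compound 3 stands highest of the three numbers, but only its gap to compound 2 is beyond the scatter; its gap to compound 1 is within it, so no order between compound 3 and compound 1 can be read. Going by the values given here, the one measured step, a number 13 percentage points higher from compound 2 to compound 3 (beyond the scatter), concerns a change on the same oxygen next to a carbonyl group, but it swaps one small chain for another and says nothing direct about a ring entering there.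

Compound 4 `CC1=C(C(=O)OCc2ccccc2)C(c2cccs2)NC(=O)N1C` differs from compound 3 by benzyl in place of isopropyl on an oxygen next to a carbonyl group. The closest guide is compound 1, which carries the same benzyl group and gives a number within the scatter of compound 3. Compound 4 is therefore expected to show a step of a number 6 percentage points lower from compound 3 to compound 4 (within the scatter) in this assay, that is, no change beyond the scatter. The estimate for compound 4 is 11%, with a range from 0% to 25%.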

Compound 4, a percentage reported as inhibition, at one concentration (the size of the read-out at that concentration, not a potency): 18%
Compound 4: middle estimate off by 7 percentage points, on the low side; low and high end bracket the measured number.
By their numbers in this assay, from the lowest: compounds 2, 1, 3 and 4 (each within the scatter of the next, the first and the last beyond it).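

In this assay the benzyl group on an oxygen next to a carbonyl group, in place of isopropyl, gives a number 1 percentage points higher from compound 3 to compound 4 (within the scatter), so a six-membered aromatic ring entering at this position leaves the reading unchanged within the scatter. Phenyl in place of ethyl on a saturated chain carbon bound to that oxygen gives a number 14 percentage points higher from compound 2 to compound 4 (beyond the scatter), a second step beyond the scatter away from the propyl ester beside a number 13 percentage points higher from compound 2 to compound 3 (beyond the scatter). Methyl in place of hydrogen on an amide-type nitrogen in a ring, with benzyl kept, gives a number 10 percentage points higher from compound 1 to compound 4 (within the scatter), so no effect of that methyl can be read.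

The data at hand offer no explanation for these steps. The compounds shown leave open how a longer chain on this oxygen, or an amine or a carboxylic acid on the benzyl ring, would read.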